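One Stereocentre Drawn Three Ways

This account rests on a few compounds, and the source may have more. Where it says the series, first, only, none or still open, it means among the compounds named here.

Measured in a physicochemical assay for solubility, read by chemiluminescence, measured as kinetic solubility; a lower number here means a less soluble compound, a higher number a more soluble compound:
- compound 1 `O=C([C@@H]1CCCN1)N1CCC2(CCN(c3nccc(NCc4ccc(Cl)cc4Cl)n3)CC2)C1`: 165 ug/mL
- compound 2 `O=C(C1CCCN1)N1CCC2(CCN(c3nccc(NCc4ccc(Cl)cc4Cl)n3)CC2)C1`: 79 ug/mL

Compound 2 has the lower of the two numbers. For the measured compounds named here, the one measured step, a 2.1-fold lower number from compound 1 to compound 2 (0.32 log units; beyond the scatter), is modest, and the only difference behind it is the fact that one of compounds 1 and 2 is drawn with a defined configuration and the other without, at the place where they differ.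

Compound 3 `O=C([C@H]1CCCN1)N1CCC2(CCN(c3nccc(NCc4ccc(Cl)cc4Cl)n3)CC2)C1` has the same atoms and bonds as compound 2: the two compounds have the same atoms and bonds; at least one stereo element is drawn with a configuration in one of them and without one in the other: 1 of 1 stereo elements differ; a stereocentre at a saturated ring carbon is drawn without a configuration in compound 2 and R in compound 3. Going by the values given here, only that single step bears on this change, and it was measured on the S form, not the R form. Among the compounds with values here, a small rise in this assay, no larger than that step, therefore seems likely. The expected change is a 1.3-fold higher number from compound 2 to compound 3 (0.10 log units; within the scatter). For compound 3 the estimated value is 100 ug/mL, with an expected range of 45 ug/mL to 210 ug/mL.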

Compound 3, solubility: 180 ug/mL
Beside the measured number, compound 3's estimate is 1.8-fold (0.26 log units) below it, and the stated range covers the measured number.
By their numbers in this assay, from the lowest: compound 2; then compounds 1 and 3 (each within the scatter of the next).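

Compound 1, drawn S, and compound 3, drawn R, cannot be told apart in this assay (a 1.1-fold higher number from compound 1 to compound 3 (0.04 log units; within the scatter)), so the drawn configuration at this saturated ring carbon makes no readable difference here. Compound 2, drawn without a configuration, now has the lower number against the R form too (a 2.3-fold higher number from compound 2 to compound 3 (0.36 log units; beyond the scatter)), so its gap is not peculiar to the S form.

Why compound 2 reads lower than both defined forms stays open. So does whether the two forms would still match with a carboxylic acid or a longer chain in place of this ring.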